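A few compounds are considered here, and "the series" means these few. Any claim that something is new, unique, unknown or untested is made for them only; others in the source may bear on it.

Measured compounds:
- compound 1, `O=C(COc1ccc(C(=O)/C=C/c2ccccc2Br)cc1)N[C@H]1CCOC1=O` — 12200 nM
- compound 2, `CC(C)c1ccc(NCC(=O)N[C@H]2CCOC2=O)cc1` — > 64000 nM
- compound 3, `O=C(CNc1ccc(Cl)cc1)N[C@H]1CCOC1=O` — > 64000 nM

In a functional assay on MGC-803 cells (Homo sapiens) for antiproliferative activity, read by MTT assay, with a stated time of 72 h (on this read-out higher numbers stand for weaker inhibition and lower numbers for stronger inhibition), compound 1 gives 12200 nM, the only number among the three results shown. Compound 2 reaches only > 64000 nM, which is a limit of the assay and not a number. Compound 3 likewise stops at > 64000 nM, again a limit rather than a number. Within the data shown here, the one step between measured compounds, a step that the two limits leave unreadable from compound 2 to compound 3, therefore cannot be read, since both of its ends sit at the limit of > 64000 nM in this assay, at which 2 of the 3 values shown sit. Compound 2 and compound 3 also share a different core from compound 1, so neither says anything about the part of compound 1 that is now varied.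

Compound 4, `O=C(COc1ccc(C(=O)/C=C/c2ccc(F)cc2)cc1)N[C@H]1CCOC1=O`, is the next compound. It differs from compound 1 in one place: 4-fluorophenyl in place of 2-bromophenyl on a double-bonded chain carbon bound to a double-bonded chain carbon. Among the measured compounds shown here, no measured step touches this position, so there is no measured basis for expecting a shift beyond the usual scatter in this assay in either direction. The estimate for compound 4 is therefore placed close to compound 1, at 15000 nM, with a range from 5000 nM to 50000 nM, which means an expected step of a 1.2-fold higher number from compound 1 to compound 4 (0.09 log units; within the scatter).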

Compound 4, half-maximal inhibitory concentration: > 64000 nM
Compound 4 gave a limit, no number (the forecaster's own chance of this, stated with the estimate: 15%); middle value at least 4.2-fold (0.63 log units) from the limit.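

In this assay, among these compounds, the group on a double-bonded chain carbon bound to a double-bonded chain carbon is the first place in the core of compound 1 where a change can be read: putting 4-fluorophenyl in place of 2-bromophenyl gives an at least 5.2-fold higher number from compound 1 to compound 4 (0.71 log units; beyond the scatter). This position is therefore not indifferent to the group it carries, since keeping the shared core does not by itself keep the measurable result of compound 1. Compound 4 gives > 64000 nM, which is a limit of the assay and not a number, so the step shows only a minimum size and its full size cannot be read: the limit of > 64000 nM in this assay, at which 3 of the 4 values shown sit.

This single change swaps the halogen and moves it on the ring at once, so the compounds shown cannot separate the two effects; 4-bromophenyl and 2-fluorophenyl would be the groups that pull them apart. From the compounds shown here alone, it also stays open whether a plain phenyl, a 2-chlorophenyl or a 2-methoxyphenyl at this position would match compound 1 or give a clearly lower number.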